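Methoxy to hydroxy on a naphthoquinone cytotoxicity series

The source may report more compounds than this note shows. Statements on the series, on what has been measured and on what is new or still open speak of the compounds shown alone.

Measured compounds:
compound 1, `CC(C)(CNC(=O)c1ccccc1)CC1=C(O)C(=O)c2ccccc2C1=O`, 50500 nM
compound 2, `COC1=C(CC(C)(C)CNC(=O)c2ccccc2)C(=O)c2ccccc2C1=O`, 12300 nM
compound 3, `COC1=C(CC(C)(C)CNC(=O)c2ccc3ccccc3c2OC)C(=O)c2ccccc2C1=O`, 60600 nM

In an ADME assay on Vero cells (Chlorocebus sabaeus) for cytotoxicity, read by fluorescence, with a stated time of 4 days (a higher number here means a weaker inhibitor, a lower number a stronger inhibitor), compound 2 gives 12300 nM. Compound 1 carries the change hydrogen in place of methyl on an oxygen on an unsaturated carbon relative to compound 2, and in this assay compound 1 gives 50500 nM; the step of a 4.1-fold higher number from compound 2 to compound 1 (0.61 log units; beyond the scatter) is thus of modest size, with the hydroxy compound the weaker inhibitor. Compound 3 stands furthest from compound 2 among the three and within the scatter of compound 1; the difference between the cores of compound 2 and compound 3 is not broken down here.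

Compound 4, `COc1c(C(=O)NCC(C)(C)CC2=C(O)C(=O)c3ccccc3C2=O)ccc2ccccc12`, is not yet measured. It differs from compound 3 by hydrogen in place of methyl on an oxygen on an unsaturated carbon, the same change seen between compound 2 and compound 1, at the same place. Going by the values given here, the only guide for its size is the single measured step from compound 2 to compound 1; that step was beyond the scatter and pointed toward weaker inhibition, so a step of similar direction and size is expected from compound 3 to compound 4, namely a 3.0-fold higher number from compound 3 to compound 4 (0.47 log units; beyond the scatter). Since compound 3 already stands high, the expected number for compound 4 may approach the top of the tested range. Compound 4 is therefore estimated at 180000 nM, within roughly 60000 nM to 450000 nM.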

Compound 4, half-maximal inhibitory concentration: 47300 nM
The estimate for compound 4 lay 3.8-fold (0.58 log units) above the measured number, and the stated range ends above it.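

In this assay, the methoxy to hydroxy change gave a 1.3-fold lower number from compound 3 to compound 4 (0.11 log units; within the scatter), so on the core of compound 3 the step does not separate the two compounds. Set beside the earlier step, the same change did not carry over in size from one core to the other: the same change on two cores in this assay, a 4.1-fold higher number (0.61 log units; beyond the scatter) from compound 2 to compound 1 and a 1.3-fold lower number (0.11 log units; within the scatter) from compound 3 to compound 4, 5.3-fold (0.72 log units) apart, beyond the scatter of two such steps This shows that, in this series, the step seen on the core of compound 2 is no reliable guide to the step on the core of compound 3, but it does not show which difference between the two cores accounts for the gap, or how the change would behave on a third core.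

Going by these compounds, with only these two pairs, it remains open which of the two outcomes would be the more usual one across further cores. Also open, on these data alone, is how an ethoxy group or an amine in place of the methoxy would read in this assay on either core.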